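Replacing a Sulfonyl Link by a Sulfanyl Link

The source may report more compounds than this note shows. Statements on the series, on what has been measured and on what is new or still open speak of the compounds shown alone.

Compound 1, `CCOc1ccc(/C=C(\C(=O)c2ccc(Cl)cc2)S(=O)(=O)Cc2ccc(F)cc2)cc1OC`, was tested in a functional assay on DU-145 cells (Homo sapiens) for inhibition, read by trypan blue exclusion, with a stated time of 96 h (on this read-out higher numbers stand for weaker inhibition of growth and lower numbers for stronger inhibition of growth), and compound 1 gives 50000 nM. For the measured compounds named here, that is the highest number among the three compounds measured so far, meaning the weakest inhibition of growth. The nearest of the other two is compound 3, `COc1cc(OC)c(/C=C(\C(=O)c2ccc(Cl)cc2)S(=O)(=O)Cc2ccc(F)cc2)c(OC)c1`, which in this assay gives 25000 nM; this gap lies within the usual scatter, so the two compounds cannot be told apart on these numbers. The furthest is compound 2, `O=C(/C(=C/c1ccc(O)c([N+](=O)[O-])c1)SCc1ccc(Br)cc1)c1ccc([N+](=O)[O-])c(Cl)c1`, which in this assay gives 1000 nM, a gap from compound 1 that is well beyond the scatter.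

Compound 4, `CCOc1ccc(/C=C(/SCc2ccc(C)cc2)C(=O)c2ccc(Cl)cc2)cc1OC`, has not yet been measured. It is reached from compound 1 by a single change: (4-methylbenzyl)sulfanyl in place of (4-fluorobenzyl)sulfonyl on a double-bonded chain carbon bound to a carbonyl carbon and a double-bonded chain carbon. Going by the values given here, no pair of measured compounds differs in exactly this way, so the size of the step cannot be read off from the data. Among the compounds with values here, the only measured compound that lacks the sulfonyl is compound 2, and its value of 1000 nM is the lowest of the three. On that basis the step from compound 1 to compound 4 is expected to be a 10-fold lower number from compound 1 to compound 4 (1.00 log units; beyond the scatter), toward stronger inhibition. Compound 4 is therefore estimated to give 5000 nM, with a range from 1000 nM to 25000 nM.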

Compound 4, concentration for 50% growth inhibition: 25000 nM
Beside the measured number, compound 4's estimate is 5.0-fold (0.70 log units) below it; the measured number falls inside the stated range.
By their numbers in this assay, from the lowest: compound 2; then compounds 3, 4 and 1 (each within the scatter of the next).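

In this assay, for the compounds shown here, putting (4-methylbenzyl)sulfanyl in place of (4-fluorobenzyl)sulfonyl gives a 2.0-fold lower number from compound 1 to compound 4 (0.30 log units; within the scatter), and this is the first pair that isolates a change at this position, on a double-bonded chain carbon bound to a carbonyl carbon and a double-bonded chain carbon. The sulfonyl oxygens go and a methyl takes the place of the fluorine, yet compound 4 cannot be told apart from compound 1 on these numbers, so this exchange brings no readable gain in inhibition of growth in this pair. No measurement offered here explains this result.

The step alters the sulfur link and the substituent on the benzyl ring together, so the compounds shown cannot say what either part does alone, and the two parts may have offset each other or may both have done little. They also leave open how (4-fluorobenzyl)sulfanyl, or a quite different group such as an amine or a carboxylic acid, would behave on that same double-bonded chain carbon.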